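A Benzyl Group Replaces Methyl on Selenium

This account rests on a few compounds, and the source may have more. Where it says the series, first, only, none or still open, it means among the compounds named here.

Of the compounds shown here, two have so far been measured in a functional assay on K562 cells (Homo sapiens) for cytotoxicity, read by MTT assay, with a stated time of 72 h; a lower number here means a stronger inhibitor of growth, a higher number a weaker inhibitor of growth. Compound 1, `C[Se]/C(=N\C(=O)c1cccs1)NC(=O)c1cccs1`, reaches only the edge of what the measurement can report: in this assay compound 1 gives > 100000 nM, which is a limit rather than a number, (the limit of > 100000 nM in this assay, at which 1 of the 2 values shown sits). Going by the values given here, compound 2, `C[Se]/C(=N\C(=O)c1cnc2ccccc2c1)NC(=O)c1cnc2ccccc2c1`, is the only compound with an actual number: in this assay compound 2 gives 29900 nM. Compound 3, `O=C(/N=C(/NC(=O)c1cnc2ccccc2c1)[Se]Cc1ccccc1)c1cnc2ccccc2c1`, has not yet been measured. It differs from compound 2 in one place, (phenyl in place of hydrogen on a saturated chain carbon bound to a selenium atom). Among the compounds with values here, no step between two measured compounds shows what such a change does in this assay. The expected step is therefore small, either within the usual scatter or at most a modest improvement. Compound 3 is estimated at 20000 nM, with a likely range from 5000 nM to 80000 nM, which corresponds to an expected step of a 1.5-fold lower number from compound 2 to compound 3 (0.17 log units; within the scatter).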

Compound 3, concentration for total growth inhibition: 72600 nM
Estimate against measurement, compound 3: 3.6-fold (0.56 log units) below; the measured number falls inside the stated range.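

Going by these compounds alone, this is the first step measured at this place, and it goes against growth inhibition: replacing methyl with benzyl on selenium gives a 2.4-fold higher number from compound 2 to compound 3 (0.39 log units; beyond the scatter) in this assay. The saturated chain carbon bound to a selenium atom is therefore not indifferent to what it carries, and in this one pair the added phenyl brings a modest but real loss. Within the data shown here, compound 1 remains a limit and not a number, and it gives no step to set beside this one: the limit of > 100000 nM in this assay, at which 1 of the 3 values shown sits.

A single pair cannot show whether the loss belongs to the phenyl ring itself or would appear with other groups, such as an ethyl or longer chain, an amine or a carboxylic acid, on the same carbon. As far as these compounds go, whether methyl to benzyl acts the same way on the core of compound 1 also remains open.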